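The source may hold more compounds than are shown below. What is called first, only, known or untested is meant among the compounds shown, and "the series" means these compounds.

In a functional assay on COLO 205 cells (Homo sapiens) for cytotoxicity, read by MTT assay, with a stated time of 24 h (on this read-out higher numbers stand for weaker inhibition of growth and lower numbers for stronger inhibition of growth), compound 1 `COc1ccc(/C=C/C(=O)c2ccc(OCC=C(C)C)cc2O)cc1OC` reads > 100000 nM, which is a limit of the assay and not a number. Compound 2 `COc1cc(/C=C/C(=O)c2ccc(OCC=C(C)C)cc2O)cc(OC)c1OC` gives 96000 nM and compound 3 `COc1ccc(/C=C/C(=O)c2ccc(OCC=C(C)C)cc2OCC=C(C)C)cc1OC` gives 90000 nM, two values within the scatter of each other. Compound 4 `COc1cc(/C=C/C(=O)c2ccc(OCC=C(C)C)cc2OCC=C(C)C)cc(OC)c1OC` differs from compound 3 by one change: methoxy in place of hydrogen on an aromatic carbon. The same exchange appears in an at least 1.0-fold lower number from compound 1 to compound 2 (0.01 log units; that floor lies within the scatter), and the other measured step is an at least 1.1-fold lower number from compound 1 to compound 3 (0.04 log units; that floor lies within the scatter). Both start from the limit of > 100000 nM in this assay, at which 1 of the 3 values shown sits, so each gives only a floor, and both floors lie within the scatter. No step beyond the scatter is therefore expected in this assay. The estimated step is a 1.1-fold lower number from compound 3 to compound 4 (0.02 log units; within the scatter). For compound 4 the expected value is 85000 nM, with an estimated range of 40000 nM to 120000 nM.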

Compound 4, concentration for 50% growth inhibition: 78000 nM
Compound 4: the middle estimate sits 1.1-fold (0.04 log units) above what was measured; low and high end bracket the measured number.
By their numbers in this assay, from the lowest: compounds 4, 3 and 2 (each within the scatter of the next). At a limit, above all of these: compound 1.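

In this assay the methoxy exchange now has a step with no limit at either end, a 1.2-fold lower number from compound 3 to compound 4 (0.06 log units; within the scatter), and the 3-methylbut-2-en-1-yl exchange has one too, a 1.2-fold lower number from compound 2 to compound 4 (0.09 log units; within the scatter). Read between two numbers, neither exchange moves the result beyond the scatter at this position, which the steps starting from compound 1 could not show, because they rest on a limit: the limit of > 100000 nM in this assay, at which 1 of the 4 values shown sits.

The compounds shown leave open whether an amine or a carboxylic acid on this aromatic carbon would give a step beyond the scatter. They also leave open what a longer chain on the oxygen in place of 3-methylbut-2-en-1-yl would do.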